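Methyl in place of chloro: a flat step expected

This account rests on a few compounds, and the source may have more. Where it says the series, first, only, none or still open, it means among the compounds named here.

Of the compounds shown here, three have been measured so far in a functional assay on RAW264.7 cells (Mus musculus) for inhibition (a lower number here means a stronger inhibitor, a higher number a weaker inhibitor), and their numbers lie close together. Compound 1 `Cc1ccc(S(=O)(=O)NC(=O)c2cccnc2)cc1` gives 8800 nM in this assay and compound 2 `O=C(NS(=O)(=O)c1ccc(F)cc1)c1ccncc1` gives 9200 nM there. Compound 3 `O=C(NS(=O)(=O)c1ccc(Cl)cc1)c1ccncc1` gives 8900 nM and stands within the scatter of both others, so these numbers show no order among the three.

The next compound is compound 4 `Cc1ccc(S(=O)(=O)NC(=O)c2ccncc2)cc1` with methyl in place of chloro on an aromatic carbon of a six-membered aromatic ring of carbon only, para to a large group. For the measured compounds named here, the only measured step between two compounds that differ in one place is chloro in place of fluoro on an aromatic carbon a 1.0-fold lower number from compound 2 to compound 3 (0.01 log units; within the scatter) and it lies within the scatter. Going by the values given here, no measured step has methyl entering at this place, so that single step is indirect evidence. On that basis, no step beyond the scatter is expected in this assay and no direction is favoured. The estimated change is small a 1.0-fold higher number from compound 3 to compound 4 (0.00 log units; within the scatter) and stays within the scatter. Compound 4 is expected at 9000 nM with an estimated range from 5000 nM to 16000 nM for the coming measurement.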

Compound 4, half-maximal inhibitory concentration: 9800 nM
Compound 4: the middle estimate sits 1.1-fold (0.04 log units) below what was measured; the measured number falls inside the stated range.
By their numbers in this assay, from the lowest: compounds 1, 3, 2 and 4 (each within the scatter of the next).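

In this assay, methyl in place of chloro gives a 1.1-fold higher number from compound 3 to compound 4 (0.04 log units; within the scatter), and methyl in place of fluoro gives a 1.1-fold higher number from compound 2 to compound 4 (0.03 log units; within the scatter), so chloro, fluoro and methyl on this aromatic carbon, para to a large group, cannot be told apart in the numbers shown. For the compounds shown here, a second place now has a measured step as well: pyridin-4-yl in place of pyridin-3-yl on a carbonyl carbon gives a 1.1-fold higher number from compound 1 to compound 4 (0.05 log units; within the scatter), so this exchange also stays within the scatter, and the series so far shows no sensitivity to either change. No supporting evidence bears on this flat result.

Going by these compounds, the groups compared on the aromatic carbon are limited to two halogens and methyl, so it remains open whether an amine, a carboxylic acid or a longer chain there would give a step beyond the scatter. On the carbonyl carbon only pyridin-4-yl and pyridin-3-yl can be compared, which leaves open how pyridin-2-yl or an unsubstituted phenyl would read in this assay.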